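This account rests on a few compounds, and the source may have more. Where it says the series, first, only, none or still open, it means among the compounds named here.

Compound 2 `O=C(CCCCCNC(=O)c1cc(-c2ccc(F)cc2)[nH]n1)NO` gives 47600 nM in a functional assay on HepG2 cells (Homo sapiens) for antiproliferative activity, read by MTT assay, with a stated time of 96 h (on this read-out lower numbers stand for stronger inhibition of growth and higher numbers for weaker inhibition of growth), the highest of the three numbers at hand; compound 3 `Cc1cc(-c2ccc(F)cc2)nn1Cc1ccc(C(=O)NO)cc1` gives 30000 nM, a gap within the scatter, and compound 1 `CCCc1cc(-c2ccc(F)cc2)nn1Cc1ccc(C(=O)NO)cc1` gives 16800 nM, a gap beyond it. Within the data shown here, the only measured step, a 1.8-fold higher number from compound 1 to compound 3 (0.25 log units; within the scatter), alters a substituent on the shared core of compounds 1 and 3 and leaves the hydroxamic acid arm untouched, so it does not bear on a chain change. Compound 4 `O=C(CCCNC(=O)c1cc(-c2ccc(F)cc2)[nH]n1)NO` differs from compound 2 by hydroxycarbamoyl in place of 2-(hydroxycarbamoyl)ethyl on a saturated chain carbon, three bonds along the chain from an amide-type nitrogen. Among the measured compounds shown here, no measured step informs this shortening, so the expectation is a number near compound 2 with wide uncertainty. The step from compound 2 to compound 4 is expected to be a 1.3-fold higher number from compound 2 to compound 4 (0.10 log units; within the scatter). Compound 4 is thus estimated at 60000 nM, with a range of 20000 nM to 180000 nM.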

Compound 4, concentration for 50% growth inhibition: 88000 nM
Compound 4: the middle estimate sits 1.5-fold (0.17 log units) below what was measured, within the range that was stated.
By their numbers in this assay, from the lowest: compounds 1, 3, 2 and 4 (each within the scatter of the next, the first and the last beyond it).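

The step of a 1.8-fold higher number from compound 2 to compound 4 (0.27 log units; within the scatter) in this assay shows that, on this amide-linked chain, hydroxycarbamoyl in place of 2-(hydroxycarbamoyl)ethyl gives no difference beyond the scatter. Among these compounds, this is the first reading of chain length, and the two chain lengths compared here cannot be told apart on this read-out. No evidence on the cause of this step is at hand.

Open, on these data alone, is whether a chain longer than that of compound 2 would shift the number beyond the scatter. Also open, as far as these compounds go, is whether a carboxylic acid in place of the hydroxycarbamoyl end would change it.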